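The compounds below may be only part of what the source reports. "The series", "measured", "known", "first", "only" and "open" are said of these compounds alone.

Of the compounds shown here, three sharing one core have been measured in an assay on HEK293 cells for displacement of a labelled ligand from NPC1-like intracellular cholesterol transporter 1 (Homo sapiens); a lower number here means a stronger inhibitor, a higher number a weaker inhibitor. Compound 1 `CC(C)(C)c1ccc(C(=O)N2CCC3(CC2)C(=O)N(CC(=O)N2CCCC(C(N)=O)C2)CN3c2ccccc2)cc1` gives 16900 nM. Compound 2 `CC(C)(C)OC(=O)NCCNC(=O)CN1CN(c2ccccc2)C2(CCN(C(=O)c3ccc(C(C)(C)C)cc3)CC2)C1=O` gives 10900 nM, and compound 3 `COC(=O)CCCNC(=O)CN1CN(c2ccccc2)C2(CCN(C(=O)c3ccc(C4CCCCC4)cc3)CC2)C1=O` gives 2500 nM. Among these three numbers compound 2 stands second highest: its nearest neighbour is compound 1, and the step of a 1.6-fold lower number from compound 1 to compound 2 (0.19 log units; within the scatter) lies within the scatter, while compound 3 sits furthest from it, with a lower number beyond the scatter. Compound 3 differs from compound 2 in more than one place, so its number says little about any single change.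

Compound 4 `CC(C)(C)c1ccc(C(=O)N2CCC3(CC2)C(=O)N(CC(=O)NCCCCCNS(C)(=O)=O)CN3c2ccccc2)cc1` has not yet been measured. It differs from compound 2 in one place: 3-(methanesulfonamido)propyl in place of (tert-butoxycarbonyl)amino on a saturated chain carbon, two bonds along the chain from an amide-type nitrogen. Among the measured compounds shown here, the only one-place step among the measured compounds that reshapes the group attached to that carbonyl carbon is the one from compound 1 to compound 2, and that step stayed within the scatter. There is therefore no sign so far that reworking this part of the molecule moves the number much. The step is expected to be a 1.1-fold lower number from compound 2 to compound 4 (0.04 log units; within the scatter), in no firm direction. The estimate for compound 4 in this assay is 10000 nM, expected to fall between 4000 nM and 25000 nM.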

Compound 4, half-maximal inhibitory concentration: 5500 nM
The estimate for compound 4 lay 1.8-fold (0.26 log units) above the measured number; low and high end bracket the measured number.
By their numbers in this assay, from the lowest: compound 3; then compounds 4, 2 and 1 (each within the scatter of the next, the first and the last beyond it).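

In this assay, placing 3-(methanesulfonamido)propyl where (tert-butoxycarbonyl)amino stood, on a saturated chain carbon two bonds along the chain from an amide-type nitrogen, gives a 2.0-fold lower number from compound 2 to compound 4 (0.30 log units; within the scatter) and so stays at the edge of the usual scatter without passing it. Among the compounds shown here, the comparison with the ring-bearing group is clearer: (5-(methanesulfonamido)pentyl)amino in place of 3-carbamoylpiperidin-1-yl on a carbonyl carbon gives a 3.1-fold lower number from compound 1 to compound 4 (0.49 log units; beyond the scatter) and is the first one-place step in this part of the molecule to pass beyond the scatter, showing that the group on this carbonyl carbon can shift the number, though only modestly. Nothing measured here explains why either step has the size it does.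

Going from compound 2 to compound 4 changes both the chain length and the group at its end, so the two contributions cannot be told apart. A 2-(methanesulfonamido)ethyl chain would separate them, while a pentyl chain ending in a free amine or a carboxylic acid would test whether the methanesulfonamide end matters at all.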